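Solubility notes on a pyridone series: amide-capped piperidines

A few compounds are considered here, and "the series" means these few. Any claim that something is new, unique, unknown or untested is made for them only; others in the source may bear on it.

Measured so far:
- compound 1 `CC(C)n1cc(-c2ccnc3[nH]c(C4CCNCC4)cc23)ccc1=O`: 910000 nM
- compound 2 `CN(C)C(=O)CN1CCC(c2cc3c(-c4ccc(=O)n(CCC5CCOCC5)c4)ccnc3[nH]2)CC1`: 370000 nM
- compound 3 `CC(C)n1cc(-c2ccnc3[nH]c(C4CCN(CC(=O)N5CCCCC5)CC4)cc23)ccc1=O`: 79000 nM

In a physicochemical assay for solubility, in phosphate buffer, at pH 7.4 (a higher number here means a more soluble compound, a lower number a less soluble compound), compound 1 gives 910000 nM, the highest of the three numbers. Compound 2 stands nearest to it, and compound 3 furthest. Compound 4 `CC(C)n1cc(-c2ccnc3[nH]c(C4CCN(CC(=O)N(C)C)CC4)cc23)ccc1=O` is not yet measured; it differs from compound 1 in one place: (dimethylcarbamoyl)methyl in place of hydrogen on an amine nitrogen in a ring.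

Going by the values given here, one measured step bears on this change. The step of a 12-fold lower number from compound 1 to compound 3 (1.06 log units; beyond the scatter) puts a larger amide-bearing group on the same amine nitrogen in a ring, and it goes down strongly. The group entering in compound 4 is of the same kind but smaller, so a downward step is expected, probably less deep than that seen with compound 3. Among the compounds with values here, compound 2, which carries the same (dimethylcarbamoyl)methyl group on its amine nitrogen but a different group on the other nitrogen, gives 370000 nM; no step to compound 4 is available for it, so it only suggests the neighbourhood.

For compound 4 the expected step is a 3.0-fold lower number from compound 1 to compound 4 (0.48 log units; beyond the scatter). Compound 4 is estimated at 300000 nM, with a range from 110000 nM to 800000 nM.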

Compound 4, solubility: 110000 nM
Compound 4: the middle estimate sits 2.7-fold (0.44 log units) above what was measured; low and high end bracket the measured number.
By their numbers in this assay, from the lowest: compounds 3 and 4 (each within the scatter of the next); then compound 2; then compound 1.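

In this assay, going by these compounds alone, the change to (dimethylcarbamoyl)methyl on the amine nitrogen in a ring gives an 8.3-fold lower number from compound 1 to compound 4 (0.92 log units; beyond the scatter) and so shows that a smaller amide-bearing group than the one in compound 3 still lowers the number clearly at this position. The group on the carbonyl carbon makes no readable difference, with a 1.4-fold higher number from compound 3 to compound 4 (0.14 log units; within the scatter) leaving dimethylamino and piperidin-1-yl within the scatter of each other. The group on the aromatic nitrogen does make a difference with this capped amine held constant, with a 3.4-fold lower number from compound 2 to compound 4 (0.53 log units; beyond the scatter) for isopropyl in place of 2-(oxan-4-yl)ethyl.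

Open, on these data alone, is whether a group on the same amine nitrogen without an amide, such as a plain methyl or a chain ending in a carboxylic acid, would move the number differently. No measurement at hand gives a reason for any of these steps.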